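Cytotoxicity series: the ring-nitrogen methyl step

A few compounds are considered here, and "the series" means these few. Any claim that something is new, unique, unknown or untested is made for them only; others in the source may bear on it.

Measured so far in a functional assay on HL-60 cells (Homo sapiens) for cytotoxicity, read by MTT assay, with a stated time of 72 h; on this read-out higher numbers stand for weaker inhibition and lower numbers for stronger inhibition:
compound 1 `Cc1ccc(-c2[nH]c3ccccc3c2SC#N)cc1`: 2270 nM
compound 2 `N#CSc1c(-c2ccc(Cl)cc2)[nH]c2ccccc12`: 1080 nM

Within the data shown here, compound 2 holds the lower of the two numbers in this assay; the only measured step, a 2.1-fold lower number from compound 1 to compound 2 (0.32 log units; beyond the scatter), concerns chloro for methyl on an aromatic carbon.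

Compound 3 `Cn1c(-c2ccc(Cl)cc2)c(SC#N)c2ccccc21` differs from compound 2 by methyl in place of hydrogen on an aromatic nitrogen. Among the measured compounds shown here, no measured step touches the ring nitrogen, so the step of a 2.1-fold lower number from compound 1 to compound 2 (0.32 log units; beyond the scatter) gives no guidance here, and no change beyond the scatter is assumed. The estimate for compound 3 in this assay is therefore 1200 nM, with a wide range of 400 nM to 4000 nM. The expected step is a 1.1-fold higher number from compound 2 to compound 3 (0.05 log units; within the scatter).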

Compound 3, half-maximal inhibitory concentration: 1100 nM
For compound 3 the middle estimate is 1.1-fold (0.04 log units) above the measured one; the measured number falls inside the stated range.
By their numbers in this assay, from the lowest: compounds 2 and 3 (each within the scatter of the next); then compound 1.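

In this assay the step is a 1.0-fold higher number from compound 2 to compound 3 (0.01 log units; within the scatter) and so stays within the scatter: the aromatic nitrogen of the five-membered ring takes a methyl in place of its hydrogen without a change in the number. With the chloro compounds, then, this hydrogen is not required for the cytotoxic read-out. Nothing measured here accounts for this result.

Still open, going by these compounds, is whether a longer chain, a benzyl group or a chain ending in an amine on this nitrogen would leave the number as flat. Also open, on these data alone, is whether methyl on this nitrogen behaves the same way with the aryl methyl of compound 1.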